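Chloro in place of bromo: a small swap

The compounds below may be only part of what the source reports. "The series", "measured", "known", "first", "only" and "open" are said of these compounds alone.

Within the data shown here, in a functional assay on SMMC-7721 cells (Homo sapiens) for antiproliferative activity, read by MTT assay, with a stated time of 72 h (on this read-out higher numbers stand for weaker inhibition and lower numbers for stronger inhibition), two compounds have numbers so far. Compound 1 (`C#CCSc1nc(Sc2nnnn2CCN(C)C)c(C#N)c(-c2ccc(Cl)cc2)n1`) reads 7340 nM and compound 2 (`C#CCSc1nc(Sc2nccs2)c(C#N)c(-c2ccc(Br)cc2)n1`) reads 3990 nM here, two values that lie within the usual scatter of each other, so neither can be called the better one.

Compound 3 (`C#CCSc1nc(Sc2nccs2)c(C#N)c(-c2ccc(Cl)cc2)n1`) has not been measured yet. It differs from compound 2 in one place, on an aromatic carbon of a six-membered aromatic ring of carbon only, para to a large group, where chloro stands in place of bromo (chloro in place of bromo on an aromatic carbon). The rest of the structure stays the same.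

Among the measured compounds shown here, the two measured compounds differ in more than one place, so no measured step shows what this swap does. The expectation therefore rests on compound 2, with its 3990 nM as the anchor. In this assay the expected step of a 1.1-fold higher number from compound 2 to compound 3 (0.02 log units; within the scatter) is no larger than the usual scatter, and no clear direction is expected. For compound 3 the estimated value is 4200 nM (expected range 2000 nM to 8500 nM).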

Compound 3, half-maximal inhibitory concentration: 6040 nM
Compound 3: middle estimate off by 1.4-fold (0.16 log units), on the low side, within the range that was stated.
By their numbers in this assay, from the lowest: compounds 2, 3 and 1 (each within the scatter of the next).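

In this assay, among these compounds, the change from 4-bromophenyl to 4-chlorophenyl gives a 1.5-fold higher number from compound 2 to compound 3 (0.18 log units; within the scatter) and so provides the first direct reading at this position. That step lies within the scatter, which means that exchanging one halogen for the other on this aromatic carbon has no effect that can be told apart from the noise of repeated measurements. Compound 3 also opens a second one-place comparison, on the sulfur, where 1,3-thiazol-2-yl stands in place of 1-(2-(dimethylamino)ethyl)-1H-tetrazol-5-yl: a 1.2-fold lower number from compound 1 to compound 3 (0.08 log units; within the scatter) is again within the scatter, so this assay does not separate these two groups, and no other measurement is available to account for either reading.

Among the compounds shown here, because bromo and chloro are the only groups compared at this ring position, it remains open whether something other than a halogen, such as an amine, a methoxy group or a carboxylic acid, would shift the number beyond the scatter. On the sulfur, two groups are likewise too few to show how the number responds there, and a simple longer alkyl chain in that place would be an informative comparison.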